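Thieno-fused series: ring-nitrogen substituent and antiproliferative potency

A few compounds are considered here, and "the series" means these few. Any claim that something is new, unique, unknown or untested is made for them only; others in the source may bear on it.

Measured so far:
compound 1 `Cc1ccccc1CN1CCc2c(sc(NC(=O)c3ccccc3Cl)c2C(N)=O)C1` — > 50000 nM
compound 2 `NC(=O)c1c(NC(=O)c2ccccc2Cl)sc2c1CCN(Cc1c(Cl)cccc1Cl)C2` — 4740 nM
compound 3 `NC(=O)c1c(NC(=O)c2ccccc2Cl)sc2c1CCN(C(=S)Nc1ccccc1Br)C2` — 10800 nM

All three share a core and differ only in the group on the amine nitrogen in the ring. In a functional assay on MKN-74 cells (Homo sapiens) for antiproliferative activity, with a stated time of 24 h (on this read-out lower numbers stand for stronger inhibition and higher numbers for weaker inhibition), compound 1 gives > 50000 nM, which is a limit of the assay and not a number. Compound 2 gives 4740 nM and compound 3 gives 10800 nM in this assay.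

The step to compound 2 is an at least 10-fold lower number from compound 1 to compound 2 (1.02 log units; beyond the scatter); the step to compound 3 is an at least 4.6-fold lower number from compound 1 to compound 3 (0.66 log units; beyond the scatter); between the two measured substituents it is a 2.3-fold higher number from compound 2 to compound 3 (0.36 log units; beyond the scatter). Because compound 1 sits at the limit of > 50000 nM in this assay, at which 1 of the 3 values shown sits, both steps away from it are known only as lower bounds.

The not-yet-measured compound 4 `NC(=O)c1c(NC(=O)c2ccccc2Cl)sc2c1CCN(C(=S)Nc1c(Cl)cccc1Cl)C2` differs from compound 1 as follows: a group of 11 heavy atoms (7 carbon, 1 nitrogen, 1 sulfur, 2 chlorine; one six-membered aromatic ring of carbon only) in place of a group of 8 heavy atoms (8 carbon; one six-membered aromatic ring of carbon only), on an amine nitrogen in a ring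

This change carries the thiourea linkage of compound 3 together with the chlorine pattern of compound 2, so both steps out of compound 1 bear on it, and both went in the same direction with at least modest size. A step of comparable size is therefore expected in this assay, in the direction of a lower number, an at least 7.6-fold lower number from compound 1 to compound 4 (0.88 log units; beyond the scatter). Compound 4 is expected to give 6500 nM (range 2000 nM to 22000 nM).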

Compound 4, half-maximal inhibitory concentration: 4020 nM
For compound 4 the middle estimate is 1.6-fold (0.21 log units) above the measured one, within the range that was stated.
By their numbers in this assay, from the lowest: compounds 4 and 2 (each within the scatter of the next); then compound 3. At a limit, above all of these: compound 1.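

In this assay, with the thiourea linkage held, 2,6-dichlorophenyl in place of 2-bromophenyl gives a 2.7-fold lower number from compound 3 to compound 4 (0.43 log units; beyond the scatter), so the aryl group still moves the read-out on this linkage, in the same direction as the change from 2-methylphenyl to 2,6-dichlorophenyl on the saturated chain carbon. With 2,6-dichlorophenyl held, exchanging that chain carbon for the thiourea linkage gives a 1.2-fold lower number from compound 2 to compound 4 (0.07 log units; within the scatter), so among the compounds shown this position tolerates either linkage without a readable difference, and the aryl group, not the linkage, separates the values that can be compared. The remaining step, an at least 12-fold lower number from compound 1 to compound 4 (1.09 log units; beyond the scatter), is a lower bound only, as compound 1 stands at a limit of the assay and not at a number: the limit of > 50000 nM in this assay, at which 1 of the 4 values shown sits.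

Open is whether the lower numbers follow the two chlorines as such, which the compounds shown do not separate from what a 2,6-dimethylphenyl or a 2-chlorophenyl group would give on either linkage. Also open, on these data alone, is whether the sulfur of the thiourea matters at all, a question that a urea with oxygen in its place would address.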